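This account rests on a few compounds, and the source may have more. Where it says the series, first, only, none or still open, it means among the compounds named here.

Measured compounds in an ADME assay on Raji cells (Homo sapiens) for cytotoxicity, read by CellTiter-Glo and resazurin assay, with a stated time of 72 h; a higher number here means that more compound is needed for the effect, a lower number that less compound is needed:

Compound 1 `CC(C)N(Cc1cccc(OCCCCCC(=O)O)c1)C(=O)c1ccc(-c2ccoc2)cc1` gives a limit, > 26000 nM.
Compound 2 `Cc1nnc(-c2cccc(-c3ccc(C(=O)N(Cc4cccc(OCCCCCC(=O)O)c4)C(C)C)cc3)c2)o1` gives a limit, > 26000 nM.
Compound 3 `CCOc1cccc(-c2ccc(C(=O)N(Cc3cccc(OCCCCCC(=O)O)c3)C(C)C)cc2)c1` gives a limit, > 20800 nM.

Compound 3 stands at a limit of this assay, not at a number; the two other values are likewise limits, so no ordering among the three can be read. The steps between them, a step that the two limits leave unreadable from compound 1 to compound 3, a step that the two limits leave unreadable from compound 2 to compound 3 and a step that the two limits leave unreadable from compound 1 to compound 2, are all unreadable, since every end sits at a limit (the limit of > 20800 nM in this assay, at which 1 of the 3 values shown sits, (the limit of > 26000 nM in this assay, at which 2 of the 3 values shown sit)).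

Compound 4 `CC(C)N(Cc1cccc(OCCCCCC(=O)O)c1)C(=O)c1ccc(-c2ccc3cc[nH]c3c2)cc1` differs from compound 3 in one place: 1H-indol-6-yl in place of 3-ethoxyphenyl on an aromatic carbon. The measured steps that bear on this position are exchanges of the group on the same aromatic carbon, and none of them gives a readable size in this assay. No change beyond the scatter is therefore expected in this assay; rather, compound 4 is expected to sit at or beyond the limit, as every measured compound in the series does.

Estimate for compound 4 in this assay: 30000 nM, range 8000 nM to 120000 nM, which means an expected step that the limit leaves unreadable from compound 3 to compound 4 from compound 3 to compound 4, most likely reported again as a limit rather than a number.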

Compound 4, half-maximal effective concentration: > 26000 nM
Compound 4: no number, only a limit; the forecaster's own chance of this, stated with the estimate: 75%; the middle value does not contradict the limit.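

In this assay compound 4 gives > 26000 nM, a limit and not a number. No new step can be read between compound 4 and compound 1, compound 2 or compound 3, because every end sits at a limit: the limit of > 26000 nM in this assay, at which 3 of the 4 values shown sit.

The compounds shown leave open where any of the four would reach its half-maximal effect in this assay, and whether the group on this aromatic carbon changes that at all.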